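Hydrogen for Chloro: An Expected Step in Cell Potency

The source may report more compounds than this note shows. Statements on the series, on what has been measured and on what is new or still open speak of the compounds shown alone.

Two compounds in this set have numbers in a functional assay on MCF7 cells (Homo sapiens) for antiproliferative activity, read by MTT assay, with a stated time of 48 h; on this read-out lower numbers stand for stronger inhibition and higher numbers for weaker inhibition. Compound 1 `O=C1Nc2ccccc2[C@]12N[C@H](c1ccccc1)[C@H](c1ccccc1)[C@@]21CCc2c([nH]c3ccccc23)C1=O` gives 15000 nM, and compound 2 `O=C1Nc2ccccc2[C@]12N[C@H](c1ccccc1)[C@H](c1cccs1)[C@@]21CCc2c([nH]c3ccc(Cl)cc23)C1=O` gives 13000 nM. Compound 2 holds the lowest of the two numbers, but its nearest neighbour, compound 1, sits within the scatter of it, so the two cannot be told apart. Compound 3 `O=C1Nc2ccccc2[C@]12N[C@H](c1ccccc1)[C@H](c1cccs1)[C@@]21CCc2c([nH]c3ccccc23)C1=O` has not yet been measured in this assay. It differs from compound 2 in one place: hydrogen in place of chloro on an aromatic carbon. Within the data shown here, no pair of measured compounds differs by that change alone, so the direction of the step cannot be read from the data. Among the measured compounds shown here, the two measured compounds, which differ from each other in more than one place, give values close together, and that is the only guide available. On that basis compound 3 is expected to sit near compound 2. The estimated step is a 1.1-fold higher number from compound 2 to compound 3 (0.03 log units; within the scatter), and it is not expected to go beyond the scatter. The estimate for compound 3 in this assay is 14000 nM, with a range from 6000 nM to 35000 nM.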

Compound 3, half-maximal inhibitory concentration: 15000 nM
Estimate against measurement, compound 3: 1.1-fold (0.03 log units) below, and the stated range covers the measured number.
By their numbers in this assay, from the lowest: compounds 2, 1 and 3 (each within the scatter of the next).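

Hydrogen in place of chloro on an aromatic carbon of the six-membered aromatic ring gives, in this assay, a 1.2-fold higher number from compound 2 to compound 3 (0.06 log units; within the scatter), so for the first time this single change is seen on its own, and at this position it leaves the number inside the scatter. The other single change, thiophen-2-yl in place of phenyl on a saturated ring carbon, gives no change at the digits printed from compound 1 to compound 3 (within the scatter), which shows that this place on the core also separates nothing in this assay, something the earlier pair, differing in two places at once, could not show. Nothing shown here gives any measured reason why these numbers lie so close together.

What the compounds leave open is whether any other group on that aromatic carbon, such as an amine, a methoxy group or a carboxylic acid, would carry the number beyond the scatter, since chloro and hydrogen are the only two seen there. Also open is whether the two changes would stay as silent when chloro is paired with phenyl on the saturated ring carbon, a combination that does not appear among the compounds shown.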